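Swapping the basic amine on a butynylthio side chain

This account rests on a few compounds, and the source may have more. Where it says the series, first, only, none or still open, it means among the compounds named here.

Of the compounds shown here, three have been measured in a functional assay on SNB-19 cells (Homo sapiens) for antiproliferative activity, read by WST assay, with a stated time of 72 h; a higher number here means a weaker inhibitor, a lower number a stronger inhibitor. Compound 1, `Cn1c(SCC#CCN2CCCC2)nc2nc(Cl)nc(SCC#CCN3CCCC3)c21`, gives 520 nM. Compound 2, `Cn1cnc2nc(SCC#CCN3CCCCC3)nc(SCC#CCN3CCCCC3)c21`, gives 4640 nM. Compound 3, `CCN(CC)CC#CCSc1nc2c(c(=O)[nH]c(=O)n2C)n1C`, gives 1480 nM, which places it second highest of the three numbers: compound 1 sits below it beyond the scatter, and compound 2 sits above it beyond the scatter. Compounds 1 and 2 differ from compound 3 in several places at once, so no single step can be read from them.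

Compound 4, `Cn1c(SCC#CCN2CCCCC2)nc2c1c(=O)[nH]c(=O)n2C`, is not yet measured. It differs from compound 3 in one place: piperidin-1-yl in place of diethylamino on a saturated chain carbon bound to a triple-bonded carbon. Among the compounds with values here, the only guidance is that compound 2, which carries the same piperidinyl group on a different core, sits above compound 3, while compound 1 sits below it; neither comparison isolates the amine. The step from compound 3 to compound 4 is therefore expected to be small, a 1.3-fold higher number from compound 3 to compound 4 (0.11 log units; within the scatter), leaning if anything toward a weaker inhibitor. Compound 4 is estimated at 1900 nM, within 700 nM to 5000 nM.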

Compound 4, half-maximal inhibitory concentration: 166000 nM
Compound 4: the middle estimate sits 87-fold (1.94 log units) below what was measured; measured number above the stated range.
By their numbers in this assay, from the lowest: compound 1; then compound 3; then compound 2; then compound 4.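

In this assay, within the data shown here, the amine on this side chain proves decisive in a way the earlier compounds could not show, since each of them differed from compound 3 in several places at once. With the core and the rest of the chain held constant, piperidin-1-yl in place of diethylamino on a saturated chain carbon bound to a triple-bonded carbon gives a 110-fold higher number from compound 3 to compound 4 (2.05 log units; beyond the scatter), even though the two groups have the same counts of hydrogen-bond donors and acceptors and neither carries a net charge. Nothing available explains why this single change has so large an effect.

From the compounds shown here alone, it remains open whether the step would carry over to the core of compound 2, which bears the same piperidin-1-yl group. Going by these compounds, it is also open how a morpholin-4-yl or dimethylamino group would read at this place.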